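From 3,5-dimethoxyphenyl to 4-hydroxyphenyl on a shared core

The source may report more compounds than this note shows. Statements on the series, on what has been measured and on what is new or still open speak of the compounds shown alone.

Compound 1 `CCCCCCn1cnc2c(Nc3ccc(Cl)cc3)nc(N[C@H]3CC[C@H](N)CC3)nc21` gives 11700 nM
Compound 2 `CCCCCCn1cnc2c(Nc3cc(OC)cc(OC)c3)nc(N[C@H]3CC[C@H](N)CC3)nc21` gives 9100 nM

Among the compounds with values here, in a functional assay on HCC827 cells (Homo sapiens) for inhibition, read by fluorescence, with a stated time of 72 h (a lower number here means a stronger inhibitor of growth, a higher number a weaker inhibitor of growth), compound 2 cannot be told apart from compound 1, the only other measured compound. Compound 3 `CCCCCCn1cnc2c(Nc3ccc(O)cc3)nc(N[C@H]3CC[C@H](N)CC3)nc21` carries 4-hydroxyphenyl in place of 3,5-dimethoxyphenyl on a nitrogen on an aromatic ring. Within the data shown here, the one measured step at this place, a 1.3-fold lower number from compound 1 to compound 2 (0.11 log units; within the scatter), exchanged 4-chlorophenyl for 3,5-dimethoxyphenyl. Among the measured compounds shown here, no measured compound carries 4-hydroxyphenyl, so the expectation rests on that single step. The expected step is a 1.0-fold lower number from compound 2 to compound 3 (0.00 log units; within the scatter), which is none beyond the scatter. Compound 3 is expected at 9000 nM, with an estimated range of 4000 nM to 20000 nM.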

Compound 3, concentration for 50% growth inhibition: 24700 nM
Compound 3: middle estimate off by 2.7-fold (0.44 log units), on the low side; the measured number lies above the stated range.
By their numbers in this assay, from the lowest: compounds 2 and 1 (each within the scatter of the next); then compound 3.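

In this assay this position no longer looks indifferent: the earlier exchange stayed within the scatter, whereas the change to 4-hydroxyphenyl gives a 2.7-fold higher number from compound 2 to compound 3 (0.43 log units; beyond the scatter), and hydroxy in place of chloro on an aromatic carbon gives a 2.1-fold higher number from compound 1 to compound 3 (0.32 log units; beyond the scatter). Both steps are modest and run the same way, so among these three compounds, compound 3 alone stands apart.

Going by these compounds, whether this holds for the hydroxy group alone stays open, since an amine or a carboxylic acid on that aromatic ring would be needed to tell. Nothing available here explains the shift.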